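Carbamoyl to methoxycarbonyl change on the shared core

The compounds below may be only part of what the source reports. "The series", "measured", "known", "first", "only" and "open" are said of these compounds alone.

Compound 1 `Cc1cn([C@@H]2O[C@H](CO[Si](C)(C)C(C)(C)C)[C@@]3(OS(=O)(=O)C=C3NCC(=O)O)[C@H]2O[Si](C)(C)C(C)(C)C)c(=O)n(C)c1=O`, in a functional assay on HEL cells (Homo sapiens) for cytotoxicity, read by microscopy; on this read-out lower numbers stand for higher toxicity in this test and higher numbers for lower toxicity in this test: 300000 nM
Compound 2 `CCOC(=O)NC(=O)NC1=CS(=O)(=O)O[C@@]12[C@@H](CO[Si](C)(C)C(C)(C)C)O[C@@H](n1cc(C)c(=O)n(C)c1=O)[C@@H]2O[Si](C)(C)C(C)(C)C`, in this assay: 16000 nM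
Compound 3 `CCOC(=O)CNC(=O)NC1=CS(=O)(=O)O[C@@]12[C@@H](CO[Si](C)(C)C(C)(C)C)O[C@@H](n1cc(C)c(=O)n(C)c1=O)[C@@H]2O[Si](C)(C)C(C)(C)C`, in this assay: 16000 nM

Compound 3 stands level with compound 2 at the digits given, the two together holding the lowest numbers of the three; the widest gap in the set is a 19-fold lower number from compound 1 to compound 3 (1.27 log units; beyond the scatter). Compound 4 `COC(=O)NC1=CS(=O)(=O)O[C@@]12[C@@H](CO[Si](C)(C)C(C)(C)C)O[C@@H](n1cc(C)c(=O)n(C)c1=O)[C@@H]2O[Si](C)(C)C(C)(C)C` differs from compound 3 by methoxy in place of ((ethoxycarbonyl)methyl)amino on a carbonyl carbon. Among the measured compounds shown here, only one measured step touches this end of the molecule, no change at the digits printed from compound 2 to compound 3 (within the scatter), and it lies within the scatter. The large steps of a 19-fold lower number from compound 1 to compound 2 (1.27 log units; beyond the scatter) and a 19-fold lower number from compound 1 to compound 3 (1.27 log units; beyond the scatter) concern the carboxymethyl side and say nothing about removing the amino part of the carbamoyl. No step beyond the scatter is therefore expected in this assay. For compound 4 the estimated step is a 1.3-fold higher number from compound 3 to compound 4 (0.10 log units; within the scatter). Compound 4 is expected to give 20000 nM, with a range of 5000 nM to 100000 nM.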

Compound 4, minimum cytotoxic concentration: >= 50000 nM
Compound 4 gave a limit, no number; the forecaster's own chance of this, stated with the estimate: 5%; middle value at least 2.5-fold (0.39 log units) from the limit.
By their numbers in this assay, from the lowest: compounds 2 and 3 (each within the scatter of the next); then compound 1.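

On this carbonyl carbon the group does matter: methoxy in place of ((ethoxycarbonyl)methyl)amino gives an at least 3.1-fold higher number from compound 3 to compound 4 (0.49 log units; beyond the scatter), and methoxy in place of (ethoxycarbonyl)amino gives an at least 3.1-fold higher number from compound 2 to compound 4 (0.49 log units; beyond the scatter), whereas the exchange between those two amino groups stayed within the scatter. For compound 4 the value >= 50000 nM in this assay is a limit of the assay, not a number. The step from compound 1 to compound 4 cannot be read.

Still open, on these data alone, is whether the higher number follows the loss of the amino nitrogen or the shorter group. A plain amine or an ethoxy group on this carbonyl carbon would separate the two.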